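Cytotoxicity notes on a quinoxaline di-N-oxide thioether series

A few compounds are considered here, and "the series" means these few. Any claim that something is new, unique, unknown or untested is made for them only; others in the source may bear on it.

Measured compounds:
compound 1, `Cc1c(C(=O)CSc2ccc(F)cc2)[n+]([O-])c2ccccc2[n+]1[O-]`, 50 ug/mL
compound 2, `COc1ccc(SCC(=O)c2c(C)[n+]([O-])c3ccccc3[n+]2[O-])cc1`, 50 ug/mL
compound 3, `Cc1c(C(=O)CSCCNC(=O)c2ccc(F)cc2)[n+]([O-])c2ccccc2[n+]1[O-]`, > 100 ug/mL

In an ADME assay on Vero cells (Chlorocebus sabaeus) for cytotoxicity, read by MTT assay, with a stated time of 72 h (on this read-out lower numbers stand for higher toxicity in this test and higher numbers for lower toxicity in this test), compound 1 gives 50 ug/mL and compound 2 gives 50 ug/mL. The change methoxy in place of fluoro on an aromatic carbon gives no change at the digits printed from compound 1 to compound 2 (within the scatter). For compound 3 the value is a limit of this assay, not a number. The difference between the core of compound 3 and the core of compound 1 is not broken down here. Compound 4, `COc1ccc(C(=O)NCCSCC(=O)c2c(C)[n+]([O-])c3ccccc3[n+]2[O-])cc1`, is not yet measured; it differs from compound 3 by methoxy in place of fluoro on an aromatic carbon, the same change as that from compound 1 to compound 2. Because compound 3 sits at the limit of > 100 ug/mL in this assay, at which 1 of the 3 values shown sits, and the earlier step was within the scatter, compound 4 is expected to give about 150 ug/mL in this assay, a step that the limit leaves unreadable from compound 3 to compound 4 that is estimated to stay within the scatter.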

Compound 4, half-maximal cytotoxic concentration: > 100 ug/mL
Compound 4 gave a limit, no number; the forecaster's own chance of this, stated with the estimate: 80%; the middle value lies beyond the limit too.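

No step can be read from compound 3 to compound 4, because both values are limits of the assay, not numbers: the limit of > 100 ug/mL in this assay, at which 2 of the 4 values shown sit.

The compounds shown leave open whether methoxy in place of fluoro on an aromatic carbon changes cytotoxicity at all between compound 3 and compound 4.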